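This account rests on a few compounds, and the source may have more. Where it says the series, first, only, none or still open, it means among the compounds named here.

Measured so far:
compound 1, `O=C(CSc1nnnn1-c1cccc2ccccc12)Nc1ccccc1[N+](=O)[O-]`: 0.05 h
compound 2, `O=C(CCc1nnnn1-c1cccc2ccccc12)Nc1ccccc1[N+](=O)[O-]`: 0.117 h

In an in vitro ADME assay on microsomes from liver (Homo sapiens) for metabolic stability (on this read-out lower numbers stand for a shorter-lived compound and higher numbers for a longer-lived compound), compound 1 gives 0.05 h and stands at the lowest of the two numbers recorded. Compound 2 gives 0.117 h in this assay; the gap between the two lies beyond the usual scatter, so compound 1 is the shorter-lived of the pair. Among the compounds with values here, no step between measured compounds that differ in one place is available, so no measured step guides the next case.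

Compound 3, `O=C(CSc1nnnn1-c1cccc2ccccc12)Nc1ccccc1Cl`, has not yet been run in this assay. It departs from compound 1 in one place: chloro in place of nitro on an aromatic carbon. Nothing measured bears directly on this exchange. The expected step of a 1.6-fold higher number from compound 1 to compound 3 (0.20 log units; within the scatter) is small, upward if anything, and may well stay within the scatter. For compound 3 the estimate in this assay is 0.08 h, with a range from 0.03 h to 0.25 h.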

Compound 3, half-life: 0.1 h
Compound 3: middle estimate off by 1.3-fold (0.10 log units), on the low side, and the stated range covers the measured number.
By their numbers in this assay, from the lowest: compounds 1, 3 and 2 (each within the scatter of the next, the first and the last beyond it).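

In this assay, within the data shown here, chloro in place of nitro on an aromatic carbon ortho to a large group gives a 2.0-fold higher number from compound 1 to compound 3 (0.30 log units; within the scatter) and is the first single-place step read at this position. On this one pair, the nitro group with its 3 heavy atoms gives way to a chloro group of 1 heavy atom without a step beyond the scatter, so the nitro group is not needed to keep the half-life in this range. No measurement on hand accounts for this step.

Going by these compounds, it remains open whether an amine, a carboxylic acid or a methoxy group at the same position would also stay within the scatter of compound 1. Also open, on these data alone, is whether the same exchange made on compound 2 would give a step of similar size.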